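This account rests on a few compounds, and the source may have more. Where it says the series, first, only, none or still open, it means among the compounds named here.

Measured so far in a functional assay on HEK293 cells for antagonist activity at Voltage-dependent L-type calcium channel subunit alpha-1C (Oryctolagus cuniculus), read by FLIPR; on this read-out lower numbers stand for stronger inhibition and higher numbers for weaker inhibition:
- compound 1 `COC(=O)C1=C(C)NC(C)=C(C(=O)OCCCl)C1c1cccc([N+](=O)[O-])c1`: 26 nM
- compound 2 `COC(=O)C1=C(C)NC(C)=C(C(=O)OCc2ccccc2)C1c1cccc([N+](=O)[O-])c1`: 25 nM

Compound 2 stands at the lowest of the two numbers in this assay, but the nearest compound, compound 1, sits within the scatter of it, so no order between the two can be claimed.

Compound 3 `COC(=O)C1=C(C)NC(C)=C(C(=O)OC2Cc3ccccc3C2)C1c1cccc([N+](=O)[O-])c1` differs from compound 2 in one place: 2,3-dihydro-1H-inden-2-yl in place of benzyl on an oxygen next to a carbonyl group.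

For the measured compounds named here, only one measured step bears on this position, a 1.0-fold lower number from compound 1 to compound 2 (0.02 log units; within the scatter), and it lay within the scatter. On that basis the change to compound 3 is expected to give no step beyond the scatter, no change at the digits printed from compound 2 to compound 3 (within the scatter). Compound 3 is therefore estimated at 25 nM in this assay, with a range from 10 nM to 70 nM.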

Compound 3, half-maximal inhibitory concentration: 72 nM
For compound 3 the middle estimate is 2.9-fold (0.46 log units) below the measured one; the whole stated range lies below it.
By their numbers in this assay, from the lowest: compounds 2 and 1 (each within the scatter of the next); then compound 3.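

On an oxygen next to a carbonyl group, the position now shows a step beyond the scatter in this assay: 2,3-dihydro-1H-inden-2-yl in place of benzyl gives a 2.9-fold higher number from compound 2 to compound 3 (0.46 log units; beyond the scatter) and in place of 2-chloroethyl gives a 2.8-fold higher number from compound 1 to compound 3 (0.44 log units; beyond the scatter) for the same group. The position therefore does not accept every group alike, although benzyl and 2-chloroethyl could not be told apart. Nothing available explains this step.

Still open, as far as these compounds go, is whether the higher number goes with the five-membered non-aromatic ring itself. From the compounds shown here alone, how a longer chain ending in phenyl, or a chain carrying an amine, would read on this oxygen also remains open.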